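Lipophilicity notes on an ethylurea series with a bicyclic ether

This account rests on a few compounds, and the source may have more. Where it says the series, first, only, none or still open, it means among the compounds named here.

All numbers below come from a physicochemical assay for lipophilicity; a higher number here means a more lipophilic compound, a lower number a more polar compound.

compound 1 `CCNC(=O)Nc1ccc(-c2nccc([C@]34CCOC[C@H]3C4)n2)cc1`: 3.9
compound 2 `CCNC(=O)Nc1ccc(-c2nc(C(C)(C)S(C)(=O)=O)cc([C@@]34CCOC[C@@H]3C4)n2)cc1`: 4.7
compound 3 `CCNC(=O)Nc1ccc(-c2nc(C(C)(C)S(C)(=O)=O)cc([C@]34CCOC[C@H]3C4)n2)cc1`: 4.7

Compounds 2 and 3 share every atom and bond: the two compounds have the same atoms and bonds and differ only in configuration as drawn: 2 of 2 stereo elements differ (all stereocentres are inverted: mirror images); a stereocentre at a saturated ring carbon is drawn R in compound 3 and S in compound 2; a stereocentre at a saturated ring carbon is drawn S in compound 3 and R in compound 2. Their readings show no change at the digits printed from compound 2 to compound 3 (within the scatter), in line with the fact that compounds 2 and 3 differ only in the configuration as drawn. Among the measured compounds shown here, compound 2 thus stands level with compound 3, and together the two give the highest of the three numbers so far.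

Removing the substituent on the core of compound 3 gives compound 1: hydrogen in place of 1-methyl-1-(methylsulfonyl)ethyl on an aromatic carbon. This produced a number 0.80 log units lower from compound 3 to compound 1 (beyond the scatter).

Compound 4 `CCNC(=O)Nc1ccc(-c2nccc([C@@]34CCOC[C@@H]3C4)n2)cc1` is not yet measured. It differs from compound 2 in the same way that compound 1 differs from compound 3: hydrogen in place of 1-methyl-1-(methylsulfonyl)ethyl on an aromatic carbon. The place of the change is the same in both pairs. For compound 4 the step of a number 0.80 log units lower from compound 2 to compound 4 (beyond the scatter) is expected, resting on the earlier step of a number 0.80 log units lower from compound 3 to compound 1 (beyond the scatter) and on the equal readings of compound 2 and compound 3. Compound 4 is therefore estimated at 3.9, with a likely range from 3.6 to 4.2.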

Compound 4, partition coefficient: 3.9
Estimate against measurement, compound 4: no gap at the digits printed; the range from low to high includes it.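

In this assay, hydrogen in place of 1-methyl-1-(methylsulfonyl)ethyl on an aromatic carbon gives a number 0.80 log units lower from compound 2 to compound 4 (beyond the scatter), the same printed size as a number 0.80 log units lower from compound 3 to compound 1 (beyond the scatter), so the change carries over between these two cores. The two hydrogen compounds also read alike, with no change at the digits printed from compound 1 to compound 4 (within the scatter), and this agreement has a plain reading: the fact that compounds 1 and 4 differ only in the configuration as drawn. The carry-over is therefore shown only between mirror-image cores, a narrow test that says nothing about a core differing in its atoms or bonds, about any other read-out, or about any other substituent.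

The compounds shown leave open how an amine or a carboxylic acid on the same aromatic carbon would compare with either hydrogen or 1-methyl-1-(methylsulfonyl)ethyl in this assay. They also leave open whether a longer chain in place of the ethyl of the urea would shift the readings, and whether the step would keep its size on such compounds.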